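Aryl sulfonamide variation on the shared core

This account rests on a few compounds, and the source may have more. Where it says the series, first, only, none or still open, it means among the compounds named here.

Compound 2 `Cc1ccc(S(=O)(=O)NCc2cn(C[C@H](O)[C@H]3OC(=O)C(OCc4ccccc4)=C3OCc3ccccc3)nn2)cc1`: 6400 nM
Compound 1 `O=C1O[C@H]([C@@H](O)Cn2cc(CCCCl)nn2)C(OCc2ccccc2)=C1OCc1ccccc1`: 24500 nM

In a functional assay on MCF7 cells (Homo sapiens) for antiproliferative activity, read by MTT assay, with a stated time of 72 h (a higher number here means a weaker inhibitor, a lower number a stronger inhibitor), compound 2 gives 6400 nM and stands at the lower of the two numbers; compound 1 gives 24500 nM, and the step of a 3.8-fold lower number from compound 1 to compound 2 (0.58 log units; beyond the scatter) is the only one recorded. Compound 3 `O=C1O[C@H]([C@@H](O)Cn2cc(CNS(=O)(=O)c3ccc(Cl)cc3F)nn2)C(OCc2ccccc2)=C1OCc1ccccc1` differs from compound 2 by 4-chloro-2-fluorophenyl in place of 4-methylphenyl on a sulfonyl sulfur. Going by the values given here, no recorded step touches the aryl group on the sulfonyl sulfur, so the recorded step offers little guidance here. Compound 3 is therefore expected to lie close to compound 2, with a step of a 1.3-fold lower number from compound 2 to compound 3 (0.11 log units; within the scatter) that need not exceed the scatter, giving an estimated value of 5000 nM, within the range 2000 nM to 15000 nM.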

Compound 3, half-maximal inhibitory concentration: 3390 nM
Compound 3: middle estimate off by 1.5-fold (0.17 log units), on the high side; the range from low to high includes it.
By their numbers in this assay, from the lowest: compounds 3 and 2 (each within the scatter of the next); then compound 1.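

In this assay, going by these compounds alone, the first change on the sulfonyl sulfur itself, 4-chloro-2-fluorophenyl in place of 4-methylphenyl, gives a 1.9-fold lower number from compound 2 to compound 3 (0.28 log units; within the scatter), so this exchange of aryl groups does not move the number beyond the scatter. The replacement of 2-chloroethyl still stands clear of the scatter with the new aryl group, with a 7.2-fold lower number from compound 1 to compound 3 (0.86 log units; beyond the scatter) as its step. No supporting measurement bears on either step.

The compounds shown do not separate the chlorine from the fluorine. They also leave open how an amine or a carboxylic acid on the sulfonyl sulfur would read.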